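Replacing a fluoro-methylphenyl amide with a phenylphenyl amide

The compounds below may be only part of what the source reports. "The series", "measured", "known", "first", "only" and "open" are said of these compounds alone.

Compound 1 `COc1ccccc1C(=O)Nc1cccc(-c2oc3cc(-c4ccc(F)cc4)ccc3c(=O)c2O)c1`: 14500 nM
Compound 2 `Cc1ccccc1C(=O)Nc1cccc(-c2oc3cc(-c4ccc(F)cc4)ccc3c(=O)c2O)c1`: 19400 nM
Compound 3 `Cc1cc(C(=O)Nc2cccc(-c3oc4cc(-c5ccc(F)cc5)ccc4c(=O)c3O)c2)ccc1F`: 9540 nM

The three measured compounds share one core and differ only in the aryl group attached to the amide carbonyl. In a functional assay on HepG2 cells (Homo sapiens) for antiproliferative activity, read by CCK-8 assay, with a stated time of 72 h (a lower number here means a stronger inhibitor, a higher number a weaker inhibitor), compound 3 has the lowest of the three numbers. Its nearest neighbour is compound 1, the step being a 1.5-fold lower number from compound 1 to compound 3 (0.18 log units; within the scatter). The furthest step among the three is a 2.0-fold lower number from compound 2 to compound 3 (0.31 log units; beyond the scatter), a modest step that does reach beyond the scatter. Between compound 1 and compound 2 the step is a 1.3-fold higher number from compound 1 to compound 2 (0.13 log units; within the scatter).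

Compound 4 `O=C(Nc1cccc(-c2oc3cc(-c4ccc(F)cc4)ccc3c(=O)c2O)c1)c1ccc(-c2ccccc2)cc1` has not yet been measured. It differs from compound 3 in one place: 4-phenylphenyl in place of 4-fluoro-3-methylphenyl on a carbonyl carbon. Among the compounds with values here, none of the measured steps exchanges an aryl group for a 4-phenylphenyl group, so they bear on this change only indirectly. Within the data shown here, what they show is that three different aryl groups on the same carbonyl carbon held the numbers within a narrow band, with only one step beyond the scatter. On that basis no step beyond the scatter is expected from compound 3 to compound 4 in this assay. Compound 4 is therefore estimated at 9000 nM, with an expected range from 3000 nM to 30000 nM. That estimate corresponds to an expected step of a 1.1-fold lower number from compound 3 to compound 4 (0.03 log units; within the scatter).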

Compound 4, half-maximal inhibitory concentration: 88500 nM
The estimate for compound 4 lay 9.8-fold (0.99 log units) below the measured number; the measured number lies above the stated range.
By their numbers in this assay, from the lowest: compounds 3, 1 and 2 (each within the scatter of the next, the first and the last beyond it); then compound 4.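

In this assay, the carbonyl carbon of the amide had held three single-ring aryl groups in a narrow band, but it does not accept every aryl group alike: the 4-phenylphenyl group gives a 9.3-fold higher number from compound 3 to compound 4 (0.97 log units; beyond the scatter), and the same group gives a 4.6-fold higher number from compound 2 to compound 4 (0.66 log units; beyond the scatter) and a 6.1-fold higher number from compound 1 to compound 4 (0.79 log units; beyond the scatter). All three steps lie beyond the scatter, so compound 4 is the weakest of the four, and among these compounds the one group with two six-membered aromatic rings stands apart from the three groups with one such ring, a contrast that the earlier steps among single-ring groups could not reveal. Nothing measured here accounts for the loss in activity.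

With a single two-ring group, the compounds shown do not separate the effect of the second phenyl ring from that of the overall size of the group or of the loss of the fluoro and methyl substituents. They also leave open how this position would respond to a cyclohexyl group, a morpholine, or a 4-phenylphenyl group carrying a carboxylic acid on its outer ring.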